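Series notes: core demethylation from compound 1 to compound 3

The source may report more compounds than this note shows. Statements on the series, on what has been measured and on what is new or still open speak of the compounds shown alone.

Measured so far in a functional assay on A549 cells (Homo sapiens) for inhibition, read by sulforhodamine B assay, with a stated time of 48 h; a higher number here means a weaker inhibitor of growth, a lower number a stronger inhibitor of growth:
Compound 1, `COC1=C(OC)[C@H](O)[C@H](C/C=C(\C)CC/C=C(\C)C[C@H](O)/C=C(\C)CO)[C@@H](C)C1=O`: 12000 nM
Compound 2, `COC1=C(OC)[C@H](O)[C@H](C/C=C(\C)CC/C=C(\C)CC/C=C(\C)CO)[C@@H](C)C1=O`: 8200 nM

Compound 1 stands with the highest of the two numbers in this assay, and its nearest neighbour is compound 2, with a 1.5-fold lower number from compound 1 to compound 2 (0.17 log units; within the scatter). That single step puts hydrogen in place of hydroxy on a saturated chain carbon bound to a double-bonded chain carbon and a saturated chain carbon, and it stays within the scatter, so the two compounds are not distinguishable on these numbers.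

Compound 3, `COC1=C(O)[C@H](O)[C@H](C/C=C(\C)CC/C=C(\C)C[C@H](O)/C=C(\C)CO)[C@@H](C)C1=O`, differs from compound 1 in another place: hydrogen in place of methyl on an oxygen on an unsaturated carbon. Within the data shown here, the change sits on an oxygen on an unsaturated carbon of the shared core, not on the chain, so the one measured step does not bear on it, and no measured step touches that oxygen. Without a relevant step, no movement beyond the scatter is expected in this assay, in either direction.

Compound 3 is therefore expected to give 12000 nM, with a range from 4000 nM to 36000 nM. The expected step is no change at the digits printed from compound 1 to compound 3 (within the scatter).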

Compound 3, concentration for 50% growth inhibition: > 30000 nM
Compound 3 gave a limit, no number; the forecaster's own chance of this, stated with the estimate: 10%; middle value at least 2.5-fold (0.39 log units) from the limit.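

In this assay, compound 3 carries a limit and not a number, > 30000 nM. Even so, this oxygen on an unsaturated carbon of the shared core proves to be a position that matters in this assay: hydrogen in place of methyl gives an at least 2.5-fold higher number from compound 1 to compound 3 (0.39 log units; beyond the scatter), the only step shown that passes the scatter, whereas the change on the chain gave a 1.5-fold lower number from compound 1 to compound 2 (0.17 log units; within the scatter). On these data alone, the methoxy to hydroxy change therefore weakens growth inhibition, but its full size stays unknown, and the reading is bounded on one side only: the limit of > 30000 nM in this assay, at which 1 of the 3 values shown sits.

The compounds shown leave open whether the methyl itself is what counts on this oxygen, or whether an ethyl or a benzyl group there, or an amine in place of the methoxy, would hold the level of compound 1. They also leave open whether the other methoxy on the shared core responds to the same change, and whether the step from compound 1 to compound 3 would repeat on the chain of compound 2, which lacks the chain hydroxy.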